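The compounds below may be only part of what the source reports. "The series", "measured", "known", "first", "only" and "open" are said of these compounds alone.

Measured so far in a functional assay on PC-3 cells (Homo sapiens) for antiproliferative activity; a higher number here means a weaker inhibitor of growth, a lower number a stronger inhibitor of growth:
compound 1, `c1ccc(-c2cc(-c3cccnc3)nc(-c3ccccn3)c2)cc1`, gives 0.28 ug/mL;
compound 2, `c1ccc(-c2cc(-c3ccccn3)nc(-c3ccccn3)c2)cc1`, gives 0.017 ug/mL;
compound 3, `c1ccc(-c2cc(-c3ccsc3)cc(-c3cccnc3)n2)nc1`, gives 0.054 ug/mL.

Compound 2 has the lowest number of the three: compound 3 stands a 5.2-fold lower number from compound 1 to compound 3 (0.71 log units; beyond the scatter) away from compound 1, while compound 2 is reached by a 16-fold lower number from compound 1 to compound 2 (1.22 log units; beyond the scatter). Compound 4, `c1ccc(-c2cc(-c3cccs3)cc(-c3ccccn3)n2)nc1`, differs from compound 2 by thiophen-2-yl in place of phenyl on an aromatic carbon. Among the measured compounds shown here, the only measured step that bears on this change is the one from compound 1 to compound 3, where thiophen-3-yl in place of phenyl brought a 5.2-fold lower number from compound 1 to compound 3 (0.71 log units; beyond the scatter). A step of similar direction but uncertain size is therefore expected here, as the thiophene is joined differently and the partner groups differ. Compound 4 is expected to give about 0.01 ug/mL, within 0.003 ug/mL to 0.035 ug/mL, which means an expected 1.7-fold lower number from compound 2 to compound 4 (0.23 log units; within the scatter).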

Compound 4, concentration for 50% growth inhibition: 0.0021 ug/mL
The estimate for compound 4 lay 4.8-fold (0.68 log units) above the measured number; measured number outside the range, below it.
By their numbers in this assay, from the lowest: compound 4; then compound 2; then compound 3; then compound 1.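

In this assay, the thiophen-2-yl group opposite the ring nitrogen brings (an 8.1-fold lower number from compound 2 to compound 4 (0.91 log units; beyond the scatter)) in place of phenyl, even though compound 2 already had a low number. The lowering seen with thiophen-3-yl (a 5.2-fold lower number from compound 1 to compound 3 (0.71 log units; beyond the scatter)) therefore also appears with a thiophene joined differently and with two pyridin-2-yl groups on the core. No measurement shown accounts for the gain.

Going by these compounds, since the thiophene attachment and the pyridine partner change together between these two steps, their separate contributions remain open. On these data alone, it is also open whether an amine or a carboxylic acid on the thiophene would preserve this low number.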